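One Ring Changed on a Shared Sulfonyl Core

This account rests on a few compounds, and the source may have more. Where it says the series, first, only, none or still open, it means among the compounds named here.

Compound 1 `O=C(/C(=C\c1ccc(Cl)c([N+](=O)[O-])c1)S(=O)(=O)c1ccc(Br)cc1)c1ccc(Br)cc1` was tested in a functional assay on DU-145 cells (Homo sapiens) for inhibition, read by trypan blue exclusion, with a stated time of 96 h (a lower number here means a stronger inhibitor of growth, a higher number a weaker inhibitor of growth), where compound 1 gives 10000 nM. In this assay compound 3 `O=C(/C(=C\c1ccc(Cl)c([N+](=O)[O-])c1)Sc1ccc(Br)cc1)c1ccc(Br)cc1` gives 10000 nM, and compound 2 `O=C(/C(=C\c1ccc(O)cc1)SCc1ccc(F)cc1)c1ccc(Cl)cc1` gives 25000 nM. Compound 1 thus stands level with compound 3, the two together giving the lowest numbers of the three, while compound 2 gives a number that lies beyond the scatter above them.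

Within the data shown here, only one measured step changes a single place: no change at the digits printed from compound 1 to compound 3 (within the scatter). That step concerns the sulfur-bearing group on the shared core and says nothing about the aromatic ring on the other chain carbon.

Compound 4 `COc1cccc(OC)c1/C=C(\C(=O)c1ccc(Br)cc1)S(=O)(=O)c1ccc(Br)cc1` differs from compound 1 by 2,6-dimethoxyphenyl in place of 4-chloro-3-nitrophenyl on a double-bonded chain carbon bound to a double-bonded chain carbon. Compound 2 also carries a different ring at that place, but it differs from compound 1 in several places at once, so only its value can be noted. Among the measured compounds shown here, no measured step bears directly on this change, so the expectation is a step of no size beyond the scatter, and the estimated step is a 1.2-fold higher number from compound 1 to compound 4 (0.08 log units; within the scatter). Compound 4 is therefore expected to give about 12000 nM, estimated within a range from 4000 nM to 40000 nM.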

Compound 4, concentration for 50% growth inhibition: 10000 nM
For compound 4 the middle estimate is 1.2-fold (0.08 log units) above the measured one, within the range that was stated.
By their numbers in this assay, from the lowest: compounds 1, 3 and 4 (each within the scatter of the next); then compound 2.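

At this position, the ring change gives no change at the digits printed from compound 1 to compound 4 (within the scatter) in this assay. Among these compounds, this is the first direct reading of a ring change here, as compound 2 differs from compound 1 in several places at once and offers only its value. The group that leaves carries chloro and nitro substituents and the group that enters carries methoxy substituents, yet on this sulfonyl core the exchange produces no shift beyond the scatter, so at least these two rings cannot be told apart by this measurement. Nothing measured here explains why the exchange leaves the number in place.

Going by these compounds, it remains open whether a phenyl ring carrying an amine or a carboxylic acid, or a longer chain in place of the ring, would also leave the number in place in this assay. Also open, on these data alone, is whether the same ring change would read the same with the (4-bromophenyl)sulfanyl group of compound 3 on the shared core.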